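Trading Diethylamino for Isopropylamino on a Pyrazole Amide

A few compounds are considered here, and "the series" means these few. Any claim that something is new, unique, unknown or untested is made for them only; others in the source may bear on it.

The measured compounds:
compound 1, `COc1cc(C(=O)NC(C)C)nn1-c1ccccc1`, 24.8%
compound 2, `CCCCOc1cc(C(=O)N(CC)CC)nn1-c1ccccc1`, 44.1%

In a functional assay on the whole organism (strain Wistar) for inhibition, with Rattus norvegicus as the target, read by paw edema, with stated times of 30 min and 3 h, at a dose of 100 mg/kg by the oral route (on this read-out lower numbers stand for less inhibition and higher numbers for more inhibition at the one dose given (going by the name of the read-out)), compound 2 gives 44.1%, the higher of the two numbers; compound 1 gives 24.8%, a gap beyond the usual scatter. Among the compounds with values here, compound 1 and compound 2 differ in two places, so the two values show only that the pair sits apart, not which change carries the gap.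

Compound 3, `CCCCOc1cc(C(=O)NC(C)C)nn1-c1ccccc1`, keeps the butoxy chain of compound 2 but changes the amide: isopropylamino in place of diethylamino on a carbonyl carbon. Compound 3 thus carries the same isopropylcarbamoyl as compound 1. Within the data shown here, no measured step isolates this change. The expected step from compound 2 to compound 3, a number 10.1 percentage points lower from compound 2 to compound 3 (beyond the scatter), is a modest loss, because compound 1 with the same isopropylcarbamoyl gives 24.8%. For compound 3 the estimate is 34%, within 20% to 48%.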

Compound 3, a percentage reported as inhibition, in the whole organism at one dose (the size of the read-out at that dose, not a potency): 15.8%
Beside the measured number, compound 3's estimate is 18.2 percentage points above it, and the stated range ends above it.
By their numbers in this assay, from the lowest: compounds 3 and 1 (each within the scatter of the next); then compound 2.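

With the butoxy chain held fixed, the amide change now stands alone: isopropylamino in place of diethylamino on a carbonyl carbon, which also adds one hydrogen-bond donor, gives a number 28.3 percentage points lower from compound 2 to compound 3 (beyond the scatter) in this assay, so the group at this position clearly affects the read-out at this dose. The other single change, propyl in place of hydrogen on a saturated chain carbon bound to an oxygen on an aromatic ring, gives a number 9 percentage points lower from compound 1 to compound 3 (within the scatter), so with isopropylcarbamoyl in place, this change in chain length has no readable effect, and only the amide step lies beyond the scatter.

Still open, going by these compounds, is whether diethylamino would hold its advantage with a methoxy chain, and how a cyclic amine such as piperidine on the carbonyl carbon would compare. Nothing shown offers a measured explanation for the amide step.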